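This account rests on a few compounds, and the source may have more. Where it says the series, first, only, none or still open, it means among the compounds named here.

Among the compounds with values here, in a physicochemical assay for solubility, read by HPLC, in phosphate buffer, measured as thermodynamic solubility, with a stated time of 48 h, at pH 7.2 (a lower number here means a less soluble compound, a higher number a more soluble compound), compound 2 `CCCOc1ccc(C[C@@H](Cc2ccccc2)C(=O)O)cc1CNC(=O)c1ccc(-c2cccnc2)cc1` gives 69.5 ug/mL, the only plain number among the two values shown. Compound 1 `CCCOc1ccc(C[C@@H](Cc2ccccc2)C(=O)O)cc1CNC(=O)c1ccc(-c2cccs2)cc1` differs from it only by thiophen-2-yl in place of pyridin-3-yl, and in this assay compound 1 gives < 1 ug/mL, which is a limit of the assay rather than a number (the limit of < 1 ug/mL in this assay, at which 1 of the 2 values shown sits). The measured step was an at least 69-fold higher number from compound 1 to compound 2 (1.84 log units; beyond the scatter). Compound 3 `CCCOc1ccc(C[C@@H](Cc2ccccc2)C(=O)O)cc1CNC(=O)c1ccc(-c2ccccc2)cc1` differs from compound 2 by phenyl in place of pyridin-3-yl on an aromatic carbon. Because the step of an at least 69-fold higher number from compound 1 to compound 2 (1.84 log units; beyond the scatter) brought in pyridin-3-yl, removing it again is expected to cost solubility, an estimated drop of a 23-fold lower number from compound 2 to compound 3 (1.36 log units; beyond the scatter), giving compound 3 an expected 3 ug/mL with a range from 0.5 ug/mL to 15 ug/mL.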

Compound 3, solubility: < 1 ug/mL
Compound 3: only a limit was reported; the forecaster's own chance of this, stated with the estimate: 30%; at least 3.0-fold (0.47 log units) between middle value and limit.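

Replacing pyridin-3-yl with phenyl, which has the same ring size but only carbon atoms, gives an at least 69-fold lower number from compound 2 to compound 3 (1.84 log units; beyond the scatter) in this assay. So the ring nitrogen of pyridin-3-yl is the only difference between compound 2 and compound 3, and the low reading is no longer confined to thiophen-2-yl. The steps between compound 1 and compound 3 cannot be read, and any gap between them stays hidden: the limit of < 1 ug/mL in this assay, at which 2 of the 3 values shown sit.

Still open, as far as these compounds go, is whether pyridin-2-yl or pyridin-4-yl would match compound 2. Also open, from the compounds shown here alone, is how a phenyl carrying an amine would compare.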